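The source may hold more compounds than are shown below. What is called first, only, known or untested is meant among the compounds shown, and "the series" means these compounds.

Values so far in an in vivo ADME assay on the whole organism (Cavia porcellus); a higher number here means that the compound lasts longer, a lower number that the compound disappears faster:
- compound 1 `CCC(NC(=O)c1ccc(C(=N)N)cc1F)C(C)(C)C(=O)N1CCC(CC(=O)O)CC1` at 1.48 h
- compound 2 `CCOC(=O)CC1CCN(C(=O)C(C)(C)C(CC)NC(=O)c2ccc(C(=N)N3CCCC3)cc2F)CC1` at 2.07 h

Compound 2 stands level with compound 1 on these numbers, as the two values lie within the scatter of each other. The two compounds differ in more than one place, so their values say nothing about any single change.

Compound 3 `CCOC(=O)CC1CCN(C(=O)C(C)(C)C(CC)NC(=O)c2ccc(C(=N)N3CCC(O)CC3)cc2F)CC1` keeps the rest of compound 2 and carries 4-hydroxypiperidin-1-yl in place of pyrrolidin-1-yl on a carbon with a double bond to nitrogen. Within the data shown here, no measured pair differs in one place, so no measured step speaks directly to this change. Among the measured compounds shown here, the only anchors are compound 2 (2.07 h) and compound 1 (1.48 h), and these sit within the scatter of each other. In this assay no step beyond the scatter is therefore expected, in either direction. The estimated change is a 1.2-fold lower number from compound 2 to compound 3 (0.06 log units; within the scatter) and it rests on very little data. For compound 3 the estimated half-life is 1.8 h with an expected range from 0.9 h to 3.6 h.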

Compound 3, half-life: 3.5 h
Compound 3: the middle estimate sits 1.9-fold (0.29 log units) below what was measured, and the stated range covers the measured number.
By their numbers in this assay, from the lowest: compounds 1, 2 and 3 (each within the scatter of the next, the first and the last beyond it).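

In this assay the series now has its first comparison at a single place, a 1.7-fold higher number from compound 2 to compound 3 (0.23 log units; within the scatter) for 4-hydroxypiperidin-1-yl in place of pyrrolidin-1-yl, and compound 2 and compound 3 stand level on this read-out. On a carbon with a double bond to nitrogen whose other neighbour is an aromatic carbon, the five-membered ring can therefore give way to a six-membered ring carrying a hydrogen-bond donor and acceptor without a step beyond the scatter, a statement limited to this one pair. Nothing measured on these compounds bears on why the two values lie so close.

This single step alters ring size and adds the hydroxyl together, so the two cannot be told apart, and a plain piperidin-1-yl on the same carbon would separate them. From the compounds shown here alone, whether the same holds for a group such as morpholin-4-yl or 4-aminopiperidin-1-yl remains open, and the steps involving compound 1 cannot be read, as it differs from the other two compounds in more than one place.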